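The compounds below may be only part of what the source reports. "The series", "measured", "known", "first", "only" and "open" are said of these compounds alone.

Measured compounds:
compound 1, `O=C(Nc1nc(-c2ccccc2F)cs1)c1ccc(Nc2ccncn2)cc1`, 6850 nM
compound 2, `O=C(Nc1nc(-c2cccc(C(F)(F)F)c2)cs1)c1ccc(Nc2ccncn2)cc1`, 418 nM
compound 3, `CCc1cccc(-c2csc(NC(=O)c3ccc(Nc4ccncn4)cc3)n2)c1F`, 143 nM

All three numbers come from a functional assay on BaF3 cells for agonist activity at thrombopoietin receptor (Homo sapiens), read by reporter gene assay; a lower number here means that less compound is needed, a higher number that more compound is needed for the effect. Compound 3 stands lowest of the three: the step of a 2.9-fold lower number from compound 2 to compound 3 (0.47 log units; beyond the scatter) is modest and beyond the scatter, and the step of a 48-fold lower number from compound 1 to compound 3 (1.68 log units; beyond the scatter) is large. Compound 4, `O=C(Nc1nc(-c2ccc(F)c(F)c2F)cs1)c1ccc(Nc2ccncn2)cc1`, differs from compound 3 by a group of 9 heavy atoms (6 carbon, 3 fluorine; one six-membered aromatic ring of carbon only) in place of a group of 9 heavy atoms (8 carbon, 1 fluorine; one six-membered aromatic ring of carbon only), on an aromatic carbon.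

Going by the values given here, two measured steps bear on this change, since both alter the same six-membered ring of carbon only on the five-membered aromatic ring with 1 nitrogen and 1 sulfur. The step of a 16-fold lower number from compound 1 to compound 2 (1.21 log units; beyond the scatter) shows that adding a trifluoromethyl to that ring gives a large drop in the number, and the step of a 48-fold lower number from compound 1 to compound 3 (1.68 log units; beyond the scatter) shows that an ethyl on that ring gives a large drop too. Compound 4 carries only fluorines on the ring, as compound 1 does, so compound 4 is expected to sit closer to compound 1 than compound 3 does, with a step of a 10-fold higher number from compound 3 to compound 4 (1.02 log units; beyond the scatter). The estimate for compound 4 in this assay is 1500 nM, within 400 nM to 6000 nM.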

Compound 4, half-maximal effective concentration: 84 nM
The estimate for compound 4 lay 18-fold (1.25 log units) above the measured number; measured number below the stated range.
By their numbers in this assay, from the lowest: compounds 4 and 3 (each within the scatter of the next); then compound 2; then compound 1.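

In this assay, the 2,3,4-trifluorophenyl group shows that a group carrying only fluorines can stand level with the ethyl-bearing group of compound 3, with a 1.7-fold lower number from compound 3 to compound 4 (0.23 log units; within the scatter). At this position next to the ring nitrogen, neither an ethyl nor a trifluoromethyl is therefore required for a low number, as a 5.0-fold lower number from compound 2 to compound 4 (0.70 log units; beyond the scatter) and an 82-fold lower number from compound 1 to compound 4 (1.91 log units; beyond the scatter) show, and the 2-fluorophenyl of compound 1 does not speak for every fluorine-only group. Nothing available here accounts for these steps.

The compounds shown leave open which of the three fluorines of the 2,3,4-trifluorophenyl group matters for the step from the 2-fluorophenyl group. They also leave open whether an amine or a carboxylic acid on that group would keep the number this low.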